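The source may report more compounds than this note shows. Statements on the series, on what has been measured and on what is new or still open speak of the compounds shown alone.

Working notes on the series. Two compounds carry numbers in a functional assay on a cell-free system (plasma, Oryctolagus cuniculus) for inhibition, with stated times of 5 min, 1 min and 6 min (a lower number here means a stronger inhibitor, a higher number a weaker inhibitor), so far. Compound 1 `CCOC(=O)c1c(C)nc(-c2ccc(C#N)cc2)n1OC` gives 13400 nM in this assay. Compound 2 `CCOC(=O)c1c(C)nc(-c2cccc(C#N)c2)n1OCCC(=O)O` stands apart in that its entry in this assay is a limit of the assay and not a number: compound 2 reads > 30000 nM, as the limit of > 30000 nM in this assay, at which 1 of the 2 values shown sits. Among the compounds with values here, with no second compound at a number on the same side, the two values only show that compound 2 sits at the limit while compound 1 gives a measured value.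

The next compound is compound 3 `CCOC(=O)c1c(C)nc(-c2cccc(C#N)c2)n1OCc1ccc(OC)cc1`, which differs from compound 2 in a single place (4-methoxyphenyl in place of carboxymethyl on a saturated chain carbon bound to an oxygen on an aromatic ring).

Within the data shown here, no measured pair differing in one place is available to size this change. The expected step in this assay is an at least 2.5-fold lower number from compound 2 to compound 3 (0.39 log units; beyond the scatter), from the limit toward stronger inhibition, beyond the scatter, though with wide uncertainty. Compound 3 is therefore estimated at 12000 nM in this assay, with a range from 3000 nM to 50000 nM.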

Compound 3, half-maximal inhibitory concentration: 6830 nM
For compound 3 the middle estimate is 1.8-fold (0.24 log units) above the measured one; the range from low to high includes it.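

On a saturated chain carbon bound to an oxygen on an aromatic ring, 4-methoxyphenyl in place of carboxymethyl can now be sized in this assay, as an at least 4.3-fold lower number from compound 2 to compound 3 (0.64 log units; beyond the scatter). This size is only a lower bound, and compound 2 enters the step with a limit of the assay and not a number: the limit of > 30000 nM in this assay, at which 1 of the 3 values shown sits.

With the rest of the structure unchanged, compound 3 gives a measured value of 6830 nM.

This single pair changes the aromatic ring, the methoxy group and the loss of the carboxymethyl group together, and it does not separate their shares in the step. Also open, going by these compounds, is how an unsubstituted phenyl, a primary amide or an amine would read at this position.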